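Replacing the pyridine with a methylphenyl on the biaryl core

A few compounds are considered here, and "the series" means these few. Any claim that something is new, unique, unknown or untested is made for them only; others in the source may bear on it.

For the measured compounds named here, compound 3 `CC(Oc1ccccc1-c1ccccn1)C1=NCCN1` gives 3310 nM in an assay on CHO cells for displacement of a labelled ligand from Alpha-2B adrenergic receptor (Homo sapiens) (a higher number here means a weaker inhibitor, a lower number a stronger inhibitor), the highest of the three numbers measured so far. Compound 1 `CC(Oc1ccccc1-c1ccccc1O)C1=NCCN1` gives 1000 nM, and compound 2 `Cc1ccc(-c2ccccc2OC(C)C2=NCCN2)cc1` gives 398 nM. Compound 4 `Cc1cccc(-c2ccccc2OC(C)C2=NCCN2)c1` differs from compound 3 by 3-methylphenyl in place of pyridin-2-yl on an aromatic carbon. The step that bears on this most closely runs the other way: an 8.3-fold higher number from compound 2 to compound 3 (0.92 log units; beyond the scatter); also relevant is a 3.3-fold higher number from compound 1 to compound 3 (0.52 log units; beyond the scatter). Moving from compound 3 to compound 4 undoes that earlier swap, with 3-methylphenyl rather than 4-methylphenyl entering, so a downward step of similar size is expected, a 6.6-fold lower number from compound 3 to compound 4 (0.82 log units; beyond the scatter). Compound 4 is therefore estimated at 500 nM, with a range from 200 nM to 1500 nM.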

Compound 4, inhibition constant: 537 nM
The estimate for compound 4 lay 1.1-fold (0.03 log units) below the measured number; the measured number falls inside the stated range.
By their numbers in this assay, from the lowest: compounds 2, 4 and 1 (each within the scatter of the next, the first and the last beyond it); then compound 3.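

In this assay the gain over pyridin-2-yl is not tied to 4-methylphenyl: with a 6.2-fold lower number from compound 3 to compound 4 (0.79 log units; beyond the scatter) the 3-methylphenyl group delivers it too. With a 1.3-fold higher number from compound 2 to compound 4 (0.13 log units; within the scatter) moving the methyl group makes no real difference, and with a 1.9-fold lower number from compound 1 to compound 4 (0.27 log units; within the scatter) the 3-methylphenyl group cannot be told apart from 2-hydroxyphenyl either. Nothing available explains these differences. From the compounds shown here alone, how a phenyl ring carrying an amine or a carboxylic acid would compare on this aromatic carbon remains open.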